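The compounds below may be only part of what the source reports. "The series", "measured", "known", "first", "only" and "open" are said of these compounds alone.

Measured so far:
- compound 2 `Nc1nc([SeH])nc2ncccc12`: 31100 nM
- compound 1 `CSc1nc(NCc2ccc([Se]C)cc2)c2ccccc2n1`: > 100000 nM

Of the compounds shown here, two have been tested in an ADME assay on 184B5 cells (Homo sapiens) for cytotoxicity, read by MTT assay, with a stated time of 72 h; on this read-out lower numbers stand for stronger inhibition of growth and higher numbers for weaker inhibition of growth. Compound 2 gives 31100 nM in this assay, and this is the only plain number among the results shown. Compound 1 gives > 100000 nM in this assay, which is a limit of the assay and not a number (the limit of > 100000 nM in this assay, at which 1 of the 2 values shown sits). Within the data shown here, compound 2 therefore stands as the one compound with a measured concentration for total growth inhibition, while the other result is only a limit.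

Compound 3 `[SeH]c1nc([SeH])c2cccnc2n1` has not yet been measured. It differs from compound 2 in one place: one selenium atom in place of one nitrogen atom, on an aromatic carbon next to the ring nitrogen. Among the measured compounds shown here, no two measured compounds differ in a single place, so no measured step exists to guide this change. The expectation is a step of a 1.0-fold lower number from compound 2 to compound 3 (0.02 log units; within the scatter), which means nothing beyond the usual scatter. In this assay compound 3 is therefore expected to give about 30000 nM, with a likely range from 8000 nM to 120000 nM.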

Compound 3, concentration for total growth inhibition: 8260 nM
Compound 3: middle estimate off by 3.6-fold (0.56 log units), on the high side, within the range that was stated.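

In this assay, one selenium atom taking the place of the amino group, on an aromatic carbon next to the ring nitrogen, gives a 3.8-fold lower number from compound 2 to compound 3 (0.58 log units; beyond the scatter). Among these compounds, this is the first measured step between two compounds that differ in one place, and it shows that this position is not indifferent to what sits on it: the step is modest but beyond the scatter, and it points towards stronger inhibition of growth for the selenium compound. The compounds shown give no measurement that explains this step, and one pair in one cell assay cannot separate the loss of the amino group from the arrival of selenium.

On these data alone, it remains open whether other groups at this position, such as a hydroxyl group, a methylamine or a longer chain, would move the number in the same direction, or by a similar amount. As far as these compounds go, compound 1 gives > 100000 nM, a limit of the assay and not a number, and how it relates to the others stays open, since no single change links it to either of them.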